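The source may hold more compounds than are shown below. What is called first, only, known or untested is meant among the compounds shown, and "the series" means these compounds.

Compound 1 `O=[N+]([O-])c1ccc(S(=O)(=O)Nc2cccc3cc[nH]c23)cc1`: 7.2 ug/mL
Compound 2 `O=[N+]([O-])c1ccc(S(=O)(=O)Nc2cccc3cc(Cl)[nH]c23)cc1`: 19 ug/mL

Both values come from a functional assay on MC-38 cells (Mus musculus) for antiproliferative activity, read by colorimetric assay and MTT assay; on this read-out higher numbers stand for weaker inhibition and lower numbers for stronger inhibition. Compound 2 holds the higher of the two numbers, so it is the weaker inhibitor of the pair. For the measured compounds named here, the only measured step is a 2.6-fold higher number from compound 1 to compound 2 (0.42 log units; beyond the scatter), a modest change with chloro in place of hydrogen on an aromatic carbon.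

Compound 3 `Cc1ccc(S(=O)(=O)Nc2cccc3cc(Cl)[nH]c23)cc1` has methyl in place of nitro on an aromatic carbon, para to a large group: methyl in place of nitro on an aromatic carbon. Going by the values given here, no measured step involves either of these groups, so a 2.6-fold higher number from compound 1 to compound 2 (0.42 log units; beyond the scatter) gives only a rough sense of step size and no direction. No shift beyond the scatter is therefore expected in this assay, though the uncertainty is wide.

For compound 3 the expected value is 15 ug/mL, with an estimated range from 5 ug/mL to 45 ug/mL. This estimate means an expected 1.3-fold lower number from compound 2 to compound 3 (0.10 log units; within the scatter).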

Compound 3, half-maximal inhibitory concentration: 0.18 ug/mL
Beside the measured number, compound 3's estimate is 83-fold (1.92 log units) above it, outside the stated range (below it).
By their numbers in this assay, from the lowest: compound 3; then compound 1; then compound 2.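

In this assay, the place para to a large group on the six-membered aromatic ring of carbon only proves highly sensitive: methyl in place of nitro gives a 110-fold lower number from compound 2 to compound 3 (2.02 log units; beyond the scatter), a large step, whereas the earlier change on the core gave only a modest one, a 2.6-fold higher number from compound 1 to compound 2 (0.42 log units; beyond the scatter). With chloro kept on the core, nitro is therefore not needed for strong inhibition in this series. Nothing at hand explains the size of this step.

Open, from the compounds shown here alone, is whether the gain belongs to methyl itself or simply to the loss of nitro; an amine, a methoxy group or plain hydrogen at this place would help separate the two. Also open, going by these compounds, is whether chloro still raises the number when methyl replaces nitro, as it did with nitro present.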